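The compounds below may be only part of what the source reports. "The series", "measured", "known", "first", "only" and "open" are said of these compounds alone.

Compound 2 `CC[C@H](C)[C@@H]1C(=O)N[C@H](C2Cc3ccccc3C2)C(=O)N1[C@@H](C(=O)N1CCOCC1)c1ccc(C)nc1` carries a sec-butyl group on the saturated ring carbon of its shared core, and in an in vitro ADME assay on microsomes from liver (Rattus norvegicus) for metabolic stability (on this read-out lower numbers stand for slow clearance and higher numbers for fast clearance), compound 2 gives 1 mL.min-1.g-1. That number is level with compound 1 `CC[C@H](C)[C@@H]1C(=O)N[C@H](C2Cc3ccccc3C2)C(=O)N1[C@@H](C(=O)N(C)C)c1ccc(C)[n+]([O-])c1`, which in this assay gives 1 mL.min-1.g-1; the two together sit at the low end of the three values known. Compound 3 `Cc1ccc([C@H](C(=O)N(C)C)N2C(=O)[C@@H](C3Cc4ccccc4C3)NC(=O)[C@H]2CC(C)C)cn1`, which differs from compound 2 in several places at once, stands far away from both: in this assay compound 3 gives 3000 mL.min-1.g-1.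

Compound 4 `CCC(CC)[C@@H]1C(=O)N[C@H](C2Cc3ccccc3C2)C(=O)N1[C@@H](C(=O)N1CCOCC1)c1ccc(C)nc1` is reached from compound 2 by a single change, (pentan-3-yl in place of sec-butyl on a saturated ring carbon). The chain grows by one carbon and its defined stereocentre is lost, while the rest of the molecule is untouched. Within the data shown here, no measured pair in this set isolates such a change, so there is no step to lean on; the only guide is that compound 2 sits at the lowest value seen.

On that basis the step is expected to be small and, if anything, towards a higher number: the estimated step of a 2.0-fold higher number from compound 2 to compound 4 (0.30 log units; within the scatter) is judged to stay close to the usual scatter. Compound 4 is therefore expected to give about 2 mL.min-1.g-1 in this assay, with a plausible range from 0.7 mL.min-1.g-1 to 8 mL.min-1.g-1.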

Compound 4, intrinsic clearance in microsomes: 1 mL.min-1.g-1
The estimate for compound 4 lay 2.0-fold (0.30 log units) above the measured number; the range from low to high includes it.
By their numbers in this assay, from the lowest: compounds 1, 2 and 4 (each within the scatter of the next); then compound 3.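

In this assay, among these compounds, the replacement of sec-butyl by pentan-3-yl on a saturated ring carbon, next to the ring nitrogen, gives no change at the digits printed from compound 2 to compound 4 (within the scatter), the only step in this set that isolates a single change at this position. With the rest of the molecule untouched, neither the added carbon nor the loss of the side chain's defined stereocentre moves the clearance number beyond the scatter, so these two branched chains cannot be told apart on this read-out. Nothing shown here accounts for this, and the step stands as an observation only.

From the compounds shown here alone, what a longer chain such as heptan-4-yl, a cyclohexyl ring or a carboxylic acid would do on this ring carbon remains open, as this one step covers only two branched chains. Also open, going by these compounds, is whether the same swap would stay level with another group in place of the amide on the shared core, and the much higher number of compound 3 cannot be assigned to any single place, as that compound differs from compound 2 in several places at once.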